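The source may report more compounds than this note shows. Statements on the series, on what has been measured and on what is new or still open speak of the compounds shown alone.

Compounds measured so far in an assay on isolated protein for inhibition of pyruvate dehydrogenase E1 component subunit alpha, somatic form, mitochondrial (Sus scrofa), with a stated time of 3 min, tested at 100 uM; on this read-out higher numbers stand for more inhibition at the one concentration tested (going by the name of the read-out) and lower numbers for less inhibition:
- compound 1, `Cc1ncc(Cn2cc(CSc3nnc(-c4sc(N)nc4C)o3)nn2)c(N)n1`, giving 27.2%
- compound 2, `CNc1nc(C)c(-c2nnc(SCc3cn(Cc4cnc(C)nc4N)nn3)o2)s1`, giving 15.6%

Compound 2 stands lowest of the two numbers measured in this assay; its nearest neighbour is compound 1, which lies higher by a step that goes beyond the scatter. Among the measured compounds shown here, the one measured step is a number 11.6 percentage points lower from compound 1 to compound 2 (beyond the scatter), and it consists of a methyl in place of hydrogen on a nitrogen on an aromatic ring.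

Compound 3, `Cc1ncc(Cn2cc(CSc3nnc(-c4sc(N)nc4C(F)(F)F)o3)nn2)c(N)n1`, has not yet been measured. It differs from compound 2 as follows: 2-amino-4-(trifluoromethyl)-1,3-thiazol-5-yl in place of 4-methyl-2-(methylamino)-1,3-thiazol-5-yl on an aromatic carbon. This change has two parts. One part reverses the step that separates compound 1 from compound 2, restoring hydrogen on the ring nitrogen, and the measured step from compound 1 to compound 2 bears on it directly. For the measured compounds named here, the other part, trifluoromethyl in place of methyl on the thiazole, has no measured counterpart among the two compounds, so its effect is unknown.

On that basis compound 3 is expected to move upward from compound 2 by about a number 10.4 percentage points higher from compound 2 to compound 3 (beyond the scatter), back toward the number of compound 1. The estimate for compound 3 in this assay is 26%, with a range from 10% to 42%.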

Compound 3, a percentage reported as inhibition, at one concentration (the size of the read-out at that concentration, not a potency): 28.3%
Estimate against measurement, compound 3: 2.3 percentage points below, within the range that was stated.
By their numbers in this assay, from the lowest: compound 2; then compounds 1 and 3 (each within the scatter of the next).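

In this assay, trifluoromethyl in place of methyl on an aromatic carbon of the thiazole, with the ring amino group kept, gives a number 1.1 percentage points higher from compound 1 to compound 3 (within the scatter), so this position takes the larger group with no change that can be told from the scatter. The full replacement of 4-methyl-2-(methylamino)-1,3-thiazol-5-yl by 2-amino-4-(trifluoromethyl)-1,3-thiazol-5-yl gives a number 12.7 percentage points higher from compound 2 to compound 3 (beyond the scatter), and with the first step this places compound 2, the only compound shown with the methylamino group, apart from the two compounds that carry the free amino group. No measurement here accounts for these numbers.

What the compounds shown leave open is whether a chlorine atom, an ethyl group or a cyclopropyl group on that thiazole carbon would read like methyl and trifluoromethyl, and how trifluoromethyl behaves when paired with the methylamino group. From the compounds shown here alone, all of these numbers also come from one concentration, so any difference in potency between the compounds remains open.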